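Piperidinol series: moving from compound 3 to compound 4

The source may hold more compounds than are shown below. What is called first, only, known or untested is meant among the compounds shown, and "the series" means these compounds.

Measured compounds:
compound 1 `N#Cc1ccccc1CN1CCC(O)(Cn2cnc3c(cnn3-c3ccc(F)cc3)c2=O)CC1` — 8100 nM
compound 2 `Cc1ccc(CN2CCC(O)(Cn3cnc4c(cnn4-c4ccc(F)cc4)c3=O)CC2)cc1` — "not determined" (no result reported)
compound 3 `O=c1c2cnn(-c3ccc(F)cc3)c2ncn1CC1(O)CCN(Cc2c(Cl)cccc2Cl)CC1` — "not determined" (no result reported)

In an assay on Sf21 cells for inhibition of ubiquitin carboxyl-terminal hydrolase 7 (Homo sapiens), read by spectrophotometry, with stated times of 30 min and 2 h (a higher number here means a weaker inhibitor, a lower number a stronger inhibitor), compound 1 gives 8100 nM. For compound 2 the entry in this assay is "not determined" (no result reported). For compound 3 the entry in this assay is likewise "not determined" (no result reported); compound 3 therefore stands without a number, and a second compound of the shared core, compound 2, is in the same position. Going by the values given here, no pair of measured compounds differs in a single place, so no measured step exists on which to scale a change at this position. Among the compounds with values here, the only number in hand is that of compound 1.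

Compound 4 `COC(=O)c1ccc(CN2CCC(O)(Cn3cnc4c(cnn4-c4ccc(F)cc4)c3=O)CC2)c(Br)c1` is the next entry. Its difference from compound 3 is 2-bromo-4-(methoxycarbonyl)phenyl in place of 2,6-dichlorophenyl on a saturated chain carbon bound to an amine nitrogen in a ring. With nothing measured for compound 3, the direction of the step is open; the one available reference, compound 1 at 8100 nM, suggests the series sits in the weak range of this assay, and no change beyond the scatter is assumed in either direction. Compound 4 is therefore expected to give 6000 nM in this assay, estimated within 1200 nM to 30000 nM, with a real chance that only a limit is reported.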

Compound 4, half-maximal inhibitory concentration: 900 nM
Beside the measured number, compound 4's estimate is 6.7-fold (0.82 log units) above it, outside the stated range (below it).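

In this assay, going by these compounds alone, 2-bromo-4-(methoxycarbonyl)phenyl in place of 2-cyanophenyl, on a saturated chain carbon bound to an amine nitrogen in a ring, gives a 9.0-fold lower number from compound 1 to compound 4 (0.95 log units; beyond the scatter), the first measured change at this place and one beyond the scatter with the shared core held constant. The series is thus not tied to the range suggested by compound 1 alone, as compound 4 reaches 900 nM in this assay and the group at this place clearly affects the read-out. No available measurement explains the shift.

On these data alone, compound 2 and compound 3 carry no number, so steps to or from either cannot be read, and the effect of replacing 2,6-dichlorophenyl remains unknown. The single step also changes the bromo, methoxycarbonyl and cyano groups together, so the compounds shown cannot assign the gain to any one of them, and they leave open how a carboxylic acid or a primary amide would compare with the methoxycarbonyl group on the same ring.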